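Cytotoxicity Notes on Compound 4 Against Compounds 1 to 3

A few compounds are considered here, and "the series" means these few. Any claim that something is new, unique, unknown or untested is made for them only; others in the source may bear on it.

Values in an ADME assay on Vero cells (Chlorocebus sabaeus) for cytotoxicity, read by MTT assay, with a stated time of 72 h; a lower number here means that less compound is tolerated, a higher number that more compound is tolerated:
compound 1 `CCO/N=C(\C)CN1CCN(c2c(F)cc3c(=O)c(C(=O)O)cn(C4CC4)c3c2OC)CC1C`: 31.3 ug/mL
compound 2 `COc1c(N2CCN(C/C(C)=N/NC(=O)c3ccncc3)C(C)C2)c(F)cc2c(=O)c(C(=O)O)cn(C3CC3)c12`: 250 ug/mL
compound 3 `COc1c(N2CCN(C/C(C)=N/O)C(C)C2)c(F)cc2c(=O)c(C(=O)O)cn(C3CC3)c12`: 177 ug/mL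

Compound 1 stands lowest of the three numbers in this assay. Going from it, a 5.7-fold higher number from compound 1 to compound 3 (0.75 log units; beyond the scatter) and an 8.0-fold higher number from compound 1 to compound 2 (0.90 log units; beyond the scatter). Between the two higher compounds, a 1.4-fold lower number from compound 2 to compound 3 (0.15 log units; within the scatter), so compounds 2 and 3 are not separated by this assay.

Compound 4 `COc1c(N2CCN(O)C(C)C2)c(F)cc2c(=O)c(C(=O)O)cn(C3CC3)c12` differs from compound 1 as follows: one oxygen atom in place of a group of 7 heavy atoms (5 carbon, 1 nitrogen, 1 oxygen; no ring), on an amine nitrogen in a ring. Among the compounds with values here, no measured step removes this whole group at once. The step from compound 1 to compound 3, which puts hydrogen in place of ethyl on an oxygen, is the closest one, and the step from compound 1 to compound 2 points the same way. Both move the number upward by a modest, beyond-scatter amount, so for compound 4 a step of a 4.8-fold higher number from compound 1 to compound 4 (0.68 log units; beyond the scatter) toward a higher number is expected, landing near compounds 2 and 3 rather than near compound 1. The estimate for compound 4 in this assay is 150 ug/mL, with a range of 50 ug/mL to 400 ug/mL.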

Compound 4, half-maximal cytotoxic concentration: 19.7 ug/mL
Estimate against measurement, compound 4: 7.6-fold (0.88 log units) above; the whole stated range lies above it.
By their numbers in this assay, from the lowest: compounds 4 and 1 (each within the scatter of the next); then compounds 3 and 2 (each within the scatter of the next).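

In this assay, the hydroxy on the ring amine nitrogen does not carry the higher tolerated numbers seen with the side chains of compounds 2 and 3. There is a 9.0-fold lower number from compound 3 to compound 4 (0.95 log units; beyond the scatter), while there is a 1.6-fold lower number from compound 1 to compound 4 (0.20 log units; within the scatter), so compounds 1 and 4 are not separated. A hydroxy as such is therefore not enough at this position, since compound 3 also bears one, at the end of its chain, and the chain alone is not enough either, since compound 1 keeps that chain with ethoxy at its end. No measurement bearing on the reason for this result is available.

Open, going by these compounds, is how hydrogen or methyl on the same ring nitrogen would stand, and whether a longer chain ending in an amine or a carboxylic acid would fall with compound 1 or compound 3. Every compound shown also carries the ring methyl group, so its part in these numbers remains untested.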